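Moving a fluorine on the urea-bound phenyl ring

A few compounds are considered here, and "the series" means these few. Any claim that something is new, unique, unknown or untested is made for them only; others in the source may bear on it.

The compounds here share one core, a bicyclic heteroaromatic carrying a benzyl ether and a urea that links to a substituted phenyl ring. Compound 1 `O=C(Nc1cccc(F)c1)Nc1cc2ncncc2cc1OCc1cccc(Cl)c1` was tested in a functional assay on GBM1 cells (Homo sapiens) for antiproliferative activity, read by WST assay, with a stated time of 72 h (a higher number here means a weaker inhibitor, a lower number a stronger inhibitor), and gave 3700 nM. Compound 2 `O=C(Nc1cccc(Cl)c1)Nc1cc2ncncc2cc1OCc1ccccc1`, which carries chlorine instead of fluorine on the phenyl attached to the urea and lacks the chlorine on the benzyl group, gave 5700 nM in this assay. Within the data shown here, these two numbers lie within the usual scatter of each other, so on the numbers so far compound 1 cannot be told apart from compound 2.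

Compound 3 `O=C(Nc1ccccc1F)Nc1cc2ncncc2cc1OCc1cccc(Cl)c1` has not yet been measured. It differs from compound 1 only in 2-fluorophenyl in place of 3-fluorophenyl on an amide-type nitrogen. Among the measured compounds shown here, no pair of measured compounds shows what such a move of a single substituent does in this assay, so there is no step to lean on. With the same atoms joined only slightly differently, the step from compound 1 to compound 3 is expected to be small, and it may well fall within the scatter; a slight weakening is taken as the more likely direction, giving a 1.4-fold higher number from compound 1 to compound 3 (0.13 log units; within the scatter). Compound 3 is therefore estimated at 5000 nM in this assay, with a range from 1500 nM to 15000 nM.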

Compound 3, half-maximal inhibitory concentration: 4200 nM
For compound 3 the middle estimate is 1.2-fold (0.08 log units) above the measured one; the range from low to high includes it.
By their numbers in this assay, from the lowest: compounds 1, 3 and 2 (each within the scatter of the next).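

Moving the fluorine, with 2-fluorophenyl in place of 3-fluorophenyl on the amide-type nitrogen, gives a 1.1-fold higher number from compound 1 to compound 3 (0.06 log units; within the scatter) in this assay. Among these compounds, this is the first pair here that differs in only one place, and it shows that this particular shift of the fluorine on the urea-bound ring leaves compound 1 and compound 3 indistinguishable in this measurement. No supporting measurement is available that could explain this result.

What the compounds shown leave open is whether this ring tolerates larger changes, such as a plain phenyl ring without fluorine or one carrying an amine or a carboxylic acid in place of the fluorine, since moving one fluorine tests only a small part of what could be changed there. Going by these compounds, compound 2 differs from compound 1 in two places, the halogen on the urea-bound ring and the chlorine on the benzyl group, so the separate contribution of each of these changes also remains unknown.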